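The compounds below may be only part of what the source reports. "The series", "measured", "known", "first", "only" and "open" are said of these compounds alone.

Measured in a functional assay on HT-29 cells (Homo sapiens) for antiproliferative activity, read by sulforhodamine B assay, with a stated time of 48 h; a lower number here means a stronger inhibitor, a higher number a weaker inhibitor:
Compound 1 `CC(C)Cc1ccc(NS(=O)(=O)c2ccc(N3CCNC3=O)cc2)cc1` gives > 1000 nM, a limit of the assay rather than a number.
Compound 2 `CCCCCCOc1ccc(NS(=O)(=O)c2ccc(N3CCNC3=O)cc2)cc1` gives > 1000 nM, also a limit.
Compound 3 `Cc1ccc(NS(=O)(=O)c2ccc(N3CCNC3=O)cc2)c(C)c1` gives 180 nM.

Compound 1 thus sits at the limit of this assay, where the limit of > 1000 nM in this assay, at which 2 of the 3 values shown sit, places it, so its exact potency is not known. Compound 4 `O=C1NCCN1c1ccc(S(=O)(=O)Nc2ccc(Cl)cc2)cc1` differs from compound 1 by chloro in place of isobutyl on an aromatic carbon. Within the data shown here, the only measured step from this side, a step that the two limits leave unreadable from compound 1 to compound 2, joins two limits and gives no readable size or direction. Among the measured compounds shown here, no measured step therefore bears directly on the change to chloro. Compound 3 carries methyl groups and reaches 180 nM. Compound 4 is estimated at 350 nM, with a range of 100 nM to 1500 nM. This estimate means an expected step of an at least 2.8-fold lower number from compound 1 to compound 4 (0.45 log units; beyond the scatter), toward stronger inhibition, though held with little confidence.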

Compound 4, half-maximal inhibitory concentration: 220 nM
Estimate against measurement, compound 4: 1.6-fold (0.20 log units) above, and the stated range covers the measured number.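

Chloro on this aromatic carbon, para to a large group, gives an at least 4.5-fold lower number from compound 1 to compound 4 (0.65 log units; beyond the scatter) and an at least 4.5-fold lower number from compound 2 to compound 4 (0.65 log units; beyond the scatter) in place of isobutyl and hexyloxy, the first readable change at this position. Both steps start from a limit of the assay. The 4-chlorophenyl of compound 4 and the 2,4-dimethylphenyl of compound 3 give a 1.2-fold higher number from compound 3 to compound 4 (0.09 log units; within the scatter) and so stand within the scatter of each other.

Open, from the compounds shown here alone, is whether chloro itself matters here, or whether fluoro, bromo or a single methyl on this carbon would do the same.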